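The source may report more compounds than this note shows. Statements on the series, on what has been measured and on what is new or still open speak of the compounds shown alone.

Measured so far in a functional assay on MGC-803 cells (Homo sapiens) for antiproliferative activity, read by MTT assay, with a stated time of 48 h; on this read-out lower numbers stand for stronger inhibition and higher numbers for weaker inhibition:

compound 1, `CCOc1ccc(NC(=O)Nc2cccc(CNc3nccnc3Cl)c2)cc1`, gives 7240 nM
compound 2, `COc1ccc(NC(=O)Nc2cccc(CNc3nccnc3Cl)c2)cc1`, gives 9240 nM
compound 3, `CCc1ccccc1NC(=O)Nc1cccc(CNc2nccnc2Cl)c1`, gives 9370 nM

The three compounds share one core and differ only in the group carried on the amide-type nitrogen of the urea. Between compound 1 and compound 2 the change is hydrogen in place of methyl on a saturated chain carbon bound to an oxygen on an aromatic ring, and that step gave a 1.3-fold higher number from compound 1 to compound 2 (0.11 log units; within the scatter). Compound 3 carries a different aromatic group; its difference from compound 1 is 2-ethylphenyl in place of 4-ethoxyphenyl on an amide-type nitrogen. The steps of a 1.3-fold higher number from compound 1 to compound 3 (0.11 log units; within the scatter) and a 1.0-fold higher number from compound 2 to compound 3 (0.01 log units; within the scatter) both stay within the scatter, so the three numbers cannot be put in any order.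

Compound 4, `Cc1ccccc1NC(=O)Nc1cccc(CNc2nccnc2Cl)c1`, has not yet been measured. It differs from compound 3 by hydrogen in place of methyl on a saturated chain carbon bound to an aromatic carbon. This is the same kind of change as that from compound 1 to compound 2, but not the same: there the place was a saturated chain carbon bound to an oxygen on an aromatic ring, here it is a saturated chain carbon bound to an aromatic carbon. Resting on the step of a 1.3-fold higher number from compound 1 to compound 2 (0.11 log units; within the scatter), the expected step is a 1.1-fold higher number from compound 3 to compound 4 (0.05 log units; within the scatter). Compound 4 is therefore expected to give 10500 nM, most likely between 4500 nM and 25000 nM.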

Compound 4, half-maximal inhibitory concentration: 14000 nM
Beside the measured number, compound 4's estimate is 1.3-fold (0.12 log units) below it; measured number inside the range.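

In this assay, ethyl to methyl on the 2-ethylphenyl group gives a 1.5-fold higher number from compound 3 to compound 4 (0.17 log units; within the scatter), while the changes of aromatic group give a 1.5-fold higher number from compound 2 to compound 4 (0.18 log units; within the scatter) and a 1.9-fold higher number from compound 1 to compound 4 (0.29 log units; within the scatter), so compound 4 cannot be ranked against the other three compounds. Replacing methyl with hydrogen has now been seen in two settings, and the two steps do not differ: the same change on two cores in this assay, a 1.3-fold higher number (0.11 log units; within the scatter) from compound 1 to compound 2 and a 1.5-fold higher number (0.17 log units; within the scatter) from compound 3 to compound 4, 1.2-fold (0.07 log units) apart, within the scatter of two such steps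

This agreement means that nothing here speaks against carrying the change from one core to the other, but each step alone stays within the scatter, so neither shows that the change has any real effect, and two cores say nothing about a third.

All four numbers remain within the scatter of one another, so the compounds shown do not reveal which part of the aromatic group matters, if any does. Going by these compounds, it remains open whether an amine, a carboxylic acid or a longer chain such as butyl on that ring would give a step large enough to read.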